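This account rests on a few compounds, and the source may have more. Where it says the series, first, only, none or still open, it means among the compounds named here.

Measured in an ADME assay on CCRF-CEM cells (Homo sapiens) for antiproliferative activity, with a stated time of 48 h; on this read-out higher numbers stand for weaker inhibition and lower numbers for stronger inhibition:
- compound 1 `C=C(Br)C(=O)Nc1ccc(C(=O)/C=C/c2ccc(OC)c(OC)c2)cc1`: 1600 nM
- compound 2 `C=C(Br)C(=O)Nc1ccc(C(=O)/C=C/c2cc(OC)c(OC)c(OC)c2)cc1`: 330 nM

Compound 2 has the lower of the two numbers in this assay. Compound 3 `COc1cc(/C=C/C(=O)c2ccc(N)cc2)cc(OC)c1OC` differs from it by hydrogen in place of (1-bromoethenyl)carbonyl on a nitrogen on an aromatic ring. Among the measured compounds shown here, the only measured step, a 4.8-fold lower number from compound 1 to compound 2 (0.69 log units; beyond the scatter), is a different change, methoxy in place of hydrogen on an aromatic carbon, so it bears only loosely and sets no firm scale. A larger move towards a higher number is expected, namely a 15-fold higher number from compound 2 to compound 3 (1.18 log units; beyond the scatter). The estimated value for compound 3 is 5000 nM, with an expected range of 1200 nM to 20000 nM.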

Compound 3, half-maximal inhibitory concentration: 2300 nM
For compound 3 the middle estimate is 2.2-fold (0.34 log units) above the measured one, and the stated range covers the measured number.
By their numbers in this assay, from the lowest: compound 2; then compounds 1 and 3 (each within the scatter of the next).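

In this assay, replacing (1-bromoethenyl)carbonyl with hydrogen on the nitrogen on the aromatic ring gives a 7.0-fold higher number from compound 2 to compound 3 (0.84 log units; beyond the scatter). This shows that the nitrogen substituent, the same in compound 1 and compound 2, also bears on the read-out, although compound 3, with its plain amino group, still gives 2300 nM. Nothing available explains this step.

The compounds shown leave open how much of the step belongs to the bromine and how much to the rest of the group. An acetyl or a (1-chloroethenyl)carbonyl on the same nitrogen would separate the two.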